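The source may report more compounds than this note shows. Statements on the series, on what has been measured and on what is new or still open speak of the compounds shown alone.

Measured so far:

- compound 1, `Brc1cn2ccnc2c(-c2ccc3ncn(C4CCCCC4)c3c2)n1` — 15.2%
- compound 2, `c1csc(-c2cn3ccnc3c(-c3ccc4ncn(C5CCCCC5)c4c3)n2)c1` — 1.07%

In a functional assay on LOX IMVI cells (Homo sapiens) for inhibition, read by sulforhodamine B assay, with a stated time of 48 h, tested at 10 uM (on this read-out lower numbers stand for less inhibition and higher numbers for more inhibition at the one concentration tested (going by the name of the read-out)), compound 1 gives 15.2%, while compound 2 gives 1.07%, the lowest of the two numbers. Among the compounds with values here, the only measured step, a number 14.1 percentage points lower from compound 1 to compound 2 (beyond the scatter), swaps bromo for thiophen-2-yl at the same aromatic carbon that is changed again here.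

Compound 3, `FC(F)(F)c1cccc(-c2cn3ccnc3c(-c3ccc4ncn(C5CCCCC5)c4c3)n2)c1`, differs from compound 2 by 3-(trifluoromethyl)phenyl in place of thiophen-2-yl on an aromatic carbon. Within the data shown here, both compound 2 and compound 3 carry an aromatic ring at this carbon, so the one measured step does not speak directly to the exchange of one aryl for another; it only shows that the bromo compound sits modestly higher than the thiophen-2-yl compound, and compound 2 already lies near the bottom of the read-out. The expectation is therefore a step of a number 6.9 percentage points higher from compound 2 to compound 3 (within the scatter), within the scatter. Compound 3 is expected at 8%, in the range -8% to 25%.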

Compound 3, a percentage reported as inhibition, at one concentration (the size of the read-out at that concentration, not a potency): 3.45%
Compound 3: the middle estimate sits 4.6 percentage points above what was measured; the range from low to high includes it.
By their numbers in this assay, from the lowest: compounds 2 and 3 (each within the scatter of the next); then compound 1.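

In this assay, exchanging one aromatic ring for another at this carbon gives a number 2.4 percentage points higher from compound 2 to compound 3 (within the scatter), so thiophen-2-yl and 3-(trifluoromethyl)phenyl cannot be told apart here, despite the larger group and the different ring. Replacing bromo with 3-(trifluoromethyl)phenyl gives a number 11.8 percentage points lower from compound 1 to compound 3 (beyond the scatter), so both aryl groups shown stand apart from bromo at this position, and neither of the aryl compounds goes against that pattern. No evidence is available to explain this pattern.

Open, on these data alone, is how an amine, a carboxylic acid or a longer chain at this aromatic carbon would read in this assay. Also open, as far as these compounds go, is whether the pattern would hold with changes elsewhere on the shared core, or at concentrations other than the single one tested.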